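A few compounds are considered here, and "the series" means these few. Any claim that something is new, unique, unknown or untested is made for them only; others in the source may bear on it.

Measured so far:
Compound 1 `Fc1ccc(-c2cn3ccnc3c(-c3ccc4ncn(C5CCCCC5)c4c3)n2)cc1`: 9.02%
Compound 2 `Clc1ccc(-c2cn3ccnc3c(-c3ccc4ncn(C5CCCCC5)c4c3)n2)cc1`: 5.45%

In a functional assay on ACHN cells (Homo sapiens) for inhibition, read by sulforhodamine B assay, with a stated time of 48 h, tested at 10 uM (a higher number here means more inhibition at the concentration tested (going by the name of the read-out), a lower number less inhibition), compound 1 gives the higher of the two numbers, but a number 3.6 percentage points lower from compound 1 to compound 2 (within the scatter) lies within the scatter, so compound 1 and compound 2 stand level. Compound 3 `COc1ccccc1-c1cn2ccnc2c(-c2ccc3ncn(C4CCCCC4)c3c2)n1` differs from compound 1 by 2-methoxyphenyl in place of 4-fluorophenyl on an aromatic carbon. Among the compounds with values here, no measured step covers a change of this kind; the only step known, chloro in place of fluoro, does not bear on it. With nothing to point otherwise, the expected step is none beyond the scatter, a number 0 percentage points lower from compound 1 to compound 3 (within the scatter). Compound 3 is therefore estimated at 9%, within a range from 0% to 25%.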

Compound 3, a percentage reported as inhibition, at one concentration (the size of the read-out at that concentration, not a potency): 4.48%
For compound 3 the middle estimate is 4.5 percentage points above the measured one; the range from low to high includes it.
By their numbers in this assay, from the lowest: compounds 3, 2 and 1 (each within the scatter of the next).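

In this assay, 2-methoxyphenyl in place of 4-fluorophenyl gives a number 4.5 percentage points lower from compound 1 to compound 3 (within the scatter), and in place of 4-chlorophenyl gives a number 1 percentage points lower from compound 2 to compound 3 (within the scatter). At this position, a change of substituent and of its place on the phenyl ring, with one hydrogen-bond acceptor entering, therefore separates none of the three compounds, which stand level. No measurement offered here explains this result. Open, as far as these compounds go, is whether any other group here, such as an amine on the phenyl ring, a carboxylic acid or a longer chain, would give a step beyond the scatter.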